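Swapping the aryl group on the sulfonyl of an EP3 ligand

A few compounds are considered here, and "the series" means these few. Any claim that something is new, unique, unknown or untested is made for them only; others in the source may bear on it.

Compound 1 `O=C(NC/C=C1\CCCc2cnn(Cc3ccc(Cl)cc3Cl)c21)NS(=O)(=O)c1ccc(Cl)cc1` is the acylsulfonamide that sets the reference point here. In an assay on isolated protein for displacement of a labelled ligand from prostaglandin E2 receptor EP3 subtype (Homo sapiens), read by scintillation counting, with a stated time of 2 h (a higher number here means a weaker inhibitor, a lower number a stronger inhibitor), compound 1 gives 4 nM, the lowest of the two numbers recorded. Its nearest neighbour, compound 2 `O=C(NC/C(F)=C1\CCCc2cnn(Cc3ccc(C(F)(F)F)cc3)c21)NS(=O)(=O)c1cc(Cl)c(Cl)s1`, gives 7 nM in this assay, a difference that lies within the scatter, so the two cannot be ordered. Compound 3 `COc1ccccc1S(=O)(=O)NC(=O)NC/C=C1\CCCc2cnn(Cc3ccc(Cl)cc3Cl)c21` has not yet been measured. It differs from compound 1 in one place: 2-methoxyphenyl in place of 4-chlorophenyl on a sulfonyl sulfur. Going by the values given here, no measured pair in this set isolates such a change on the sulfonyl sulfur, so there is no step to lean on. The expectation for compound 3 is a modest weakening, with the step from compound 1 to compound 3 estimated at a 2.3-fold higher number from compound 1 to compound 3 (0.35 log units; beyond the scatter), which may still fall within the scatter. Compound 3 is therefore expected to give about 9 nM in this assay, within a range of 2.5 nM to 35 nM.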

Compound 3, inhibition constant: 62 nM
Compound 3: the middle estimate sits 6.9-fold (0.84 log units) below what was measured; measured number above the stated range.
By their numbers in this assay, from the lowest: compounds 1 and 2 (each within the scatter of the next); then compound 3.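

The sulfonyl sulfur's aryl group proves to be no neutral position on this core: with the rest of compound 1 held constant, 2-methoxyphenyl in place of 4-chlorophenyl gives a 16-fold higher number from compound 1 to compound 3 (1.19 log units; beyond the scatter) in this assay, a large step and the first in this set to isolate this position. So the affinity seen in compound 1 is not kept across every aryl group on the sulfonyl sulfur, even though the group that enters is only slightly larger by heavy-atom count and adds a hydrogen-bond acceptor. Nothing at hand accounts for the size of this step.

This single step changes both the substituent and its place on the ring, and the compounds shown cannot separate those two changes. As far as these compounds go, whether a plain phenyl or a pyridine ring on the sulfonyl sulfur would keep the binding of compound 1 also remains open.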